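Replacing the phenyl group of compound 1

The source may hold more compounds than are shown below. What is called first, only, known or untested is meant among the compounds shown, and "the series" means these compounds.

Measured in an ADME assay on a cell-free system (plasma, Rattus norvegicus) for metabolic stability, read by LC-MS, with a stated time of 1 h, at 37 degrees C, tested at 100 uM; a lower number here means that less of the compound is left, a higher number that more of the compound is left:
Compound 1 `O=C1c2ccc(OCc3cccc(-c4ccccc4)c3)cc2CN1C1CCCC1`: 95%
Compound 2 `O=C(O)c1cc(-c2cccc(COc3ccc4c(=O)n(C5CCC5)sc4c3)c2)ccc1Cl`: 91%

Compound 1, at 95%, stands level with compound 2, at 91%, as the two values lie within the usual scatter of each other. Going by the values given here, only these two compounds have numbers so far, and they differ in more than one place, so no single change can be read from them. Compound 3 `O=C(O)c1ccc(-c2cccc(COc3ccc4c(c3)CN(C3CCCC3)C4=O)c2)c(Cl)c1` keeps the core of compound 1 but has 4-carboxy-2-chlorophenyl in place of phenyl on an aromatic carbon. Compound 2 also carries a carboxy group and a chlorine, and compound 2 gives 91%, so no step beyond the scatter is expected in this assay here. The estimated step (a number 3 percentage points lower from compound 1 to compound 3 (within the scatter)) is expected to stay within the scatter, and to point slightly downward if it shows at all. For compound 3 the estimate is 92% (expected range 81% to 100%).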

Compound 3, percent of the compound remaining: 100%
Compound 3: middle estimate off by 8 percentage points, on the low side, within the range that was stated.
By their numbers in this assay, from the lowest: compounds 2, 1 and 3 (each within the scatter of the next).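

In this assay, going by these compounds alone, the exchange of phenyl for 4-carboxy-2-chlorophenyl on an aromatic carbon gives the first step that can be read for a single change, a number 5 percentage points higher from compound 1 to compound 3 (within the scatter). At this position, then, the larger group with its carboxy group and chlorine leaves the read-out within the scatter of the phenyl compound, and the two compounds stand level. No measurement shown here offers an explanation for this result.

Since the carboxy group and the chlorine enter together, the compounds shown leave open what either one does alone in this assay. They also leave open whether the same holds for a methyl ester or an amine in place of the carboxylic acid, where the read-out might separate from that of compound 1.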